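Notes on replacing 2,4-dichlorophenyl with 2,4-difluorophenyl

The source may report more compounds than this note shows. Statements on the series, on what has been measured and on what is new or still open speak of the compounds shown alone.

Measured in a functional assay on ACHN cells (Homo sapiens) (on this read-out higher numbers stand for weaker inhibition of growth and lower numbers for stronger inhibition of growth), so far:
- compound 1 `O=S(=O)(/C=C/c1ccccc1)Cc1ccc(Nc2ncnc3ccccc23)cc1` gives 58000 nM
- compound 2 `O=S(=O)(/C=C/c1ccc(Cl)cc1Cl)Cc1ccc(Nc2ncnc3ccccc23)cc1` gives 100 nM
- compound 3 `O=S(=O)(/C=C/c1ccc(Cl)cc1Cl)Cc1ccc(Nc2ncnc3ccc(Br)cc23)cc1` gives 100 nM

Compound 3 sits level with compound 2, and the two share the lowest number of the three, far from compound 1. The next change is 2,4-difluorophenyl in place of 2,4-dichlorophenyl on a double-bonded chain carbon bound to a double-bonded chain carbon and leads to compound 4 `O=S(=O)(/C=C/c1ccc(F)cc1F)Cc1ccc(Nc2ncnc3ccc(Br)cc23)cc1`, with 2,4-difluorophenyl in place of 2,4-dichlorophenyl. The closest evidence is the large step of a 580-fold lower number from compound 1 to compound 2 (2.76 log units; beyond the scatter), made at this same place. The step of no change at the digits printed from compound 2 to compound 3 (within the scatter) concerns bromo in place of hydrogen and says little here. Among the compounds with values here, no measured compound carries 2,4-difluorophenyl, so only a moderately higher number is expected in this assay, well short of the first step. The estimated step is a 5.0-fold higher number from compound 3 to compound 4 (0.70 log units; beyond the scatter). For compound 4 the estimated value is 500 nM, with an expected range of 100 nM to 5000 nM.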

Compound 4, concentration for 50% growth inhibition: 8000 nM
Estimate against measurement, compound 4: 16-fold (1.20 log units) below; measured number above the stated range.
By their numbers in this assay, from the lowest: compounds 2 and 3 (each within the scatter of the next); then compound 4; then compound 1.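

At this place on a double-bonded chain carbon, this assay gives an 80-fold higher number from compound 3 to compound 4 (1.90 log units; beyond the scatter), although the group that leaves and the group that enters have the same counts of heavy atoms, donors and acceptors. The earlier step at this place, a 580-fold lower number from compound 1 to compound 2 (2.76 log units; beyond the scatter), showed only a gain from 2,4-dichlorophenyl over phenyl; this one shows that the identity of the halogen matters as well. Nothing available here accounts for the difference.

Going by these compounds, whether 2,4-dibromophenyl or 2,4-dimethylphenyl would stay near compound 3 remains open. So does whether bromo on the shared core has any effect alongside 2,4-difluorophenyl.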